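Methoxy for Hydroxy in a Lactone Cytotoxicity Series

The source may hold more compounds than are shown below. What is called first, only, known or untested is meant among the compounds shown, and "the series" means these compounds.

Measured compounds:
compound 1, `O=C1OC[C@H](Cc2ccccc2)[C@H]1Cc1cccc(O)c1`: > 100000 nM
compound 2, `COc1cccc(C[C@H]2C(=O)OC[C@@H]2Cc2ccccc2)c1`: 66000 nM
compound 3, `O=C1OC[C@H](Cc2cccc(O)c2)[C@H]1Cc1ccc(Cl)c(Cl)c1`: 48000 nM

The three compounds were tested in a functional assay on HL-60 cells (Homo sapiens) for cytotoxicity, read by WST assay, with a stated time of 48 h; a higher number here means that more compound is needed for the effect, a lower number that less compound is needed. For compound 1 the assay returned only a limit, > 100000 nM. Compound 2 gives 66000 nM. The change between them is methyl in place of hydrogen on an oxygen on an aromatic ring, and it made a step of an at least 1.5-fold lower number from compound 1 to compound 2 (0.18 log units; that floor lies within the scatter), a floor rather than a measured size since the starting point is a limit (the limit of > 100000 nM in this assay, at which 1 of the 3 values shown sits). Compound 3 gives 48000 nM; how its core differs from that of compound 1 is not broken down here, and its value and that of compound 2 lie within the scatter of each other.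

Compound 4, `COc1cccc(C[C@H]2COC(=O)[C@@H]2Cc2ccc(Cl)c(Cl)c2)c1`, has not yet been measured. It stands to compound 3 as compound 2 stands to compound 1: the change is methyl in place of hydrogen on an oxygen on an aromatic ring, the same change at the same place. Going by the values given here, the only guide is the floor given by an at least 1.5-fold lower number from compound 1 to compound 2 (0.18 log units; that floor lies within the scatter), so compound 4 is expected to give 35000 nM, with a range from 12000 nM to 100000 nM. This expected step, a 1.4-fold lower number from compound 3 to compound 4 (0.14 log units; within the scatter), is estimated to stay within the scatter.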

Compound 4, half-maximal effective concentration: 34000 nM
Estimate against measurement, compound 4: 1.0-fold (0.01 log units) above, within the range that was stated.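

In this assay the change from hydroxy to methoxy on the second core gave a 1.4-fold lower number from compound 3 to compound 4 (0.15 log units; within the scatter), a step that stays within the scatter. The two cores therefore give no sign that the change behaves differently from one to the other, but this does not show that methoxy truly lowers the number, nor that the step has one fixed size on both cores: the same change on two cores in this assay, an at least 1.5-fold lower number (0.18 log units; that floor lies within the scatter) from compound 1 to compound 2 and a 1.4-fold lower number (0.15 log units; within the scatter) from compound 3 to compound 4; the limit leaves it open whether they differ Compound 1 has a limit here and not a number: the limit of > 100000 nM in this assay, at which 1 of the 4 values shown sits.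

The compounds shown carry only hydroxy or methoxy at this place, which leaves open whether a longer chain on that oxygen, or an amine or a carboxylic acid in place of the hydroxy, would move the number beyond the scatter. From the compounds shown here alone, whether the same change would also stay within the scatter on a core bearing a nitrile in place of the chlorines remains open as well.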